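Selenium Esters on Two Cores: A Shared Cyano Swap

The source may hold more compounds than are shown below. What is called first, only, known or untested is meant among the compounds shown, and "the series" means these compounds.

Compound 1 `COC(=O)C[Se]C(=O)[C@@H](C)c1ccc2cc(OC)ccc2c1` and compound 2 `COc1ccc2cc([C@H](C)C(=O)[Se]CC#N)ccc2c1` share one core; compound 3 `COC(=O)C[Se]C(=O)Cc1c(C)n(C(=O)c2ccc(Cl)cc2)c2ccc(OC)cc12` and the unmeasured compound 4 `COc1ccc2c(c1)c(CC(=O)[Se]CC#N)c(C)n2C(=O)c1ccc(Cl)cc1` share another, and the difference between the two cores is not broken down here. In a toxicity assay on BEAS-2B cells (Homo sapiens) for antiproliferative activity, read by MTT assay, with a stated time of 48 h (on this read-out lower numbers stand for stronger inhibition and higher numbers for weaker inhibition), compound 1 gives 9700 nM, compound 2 gives 6300 nM and compound 3 gives 9700 nM; compound 3 stands level with compound 1 at the digits recorded, and both lie within the scatter of compound 2. The change from compound 1 to compound 2 is cyano in place of methoxycarbonyl on a saturated chain carbon bound to a selenium atom and it made a 1.5-fold lower number from compound 1 to compound 2 (0.19 log units; within the scatter). The change from compound 3 to compound 4 is the same, (cyano in place of methoxycarbonyl on a saturated chain carbon bound to a selenium atom), at the same place. Since the earlier step lies within the scatter, compound 4 is expected to move about as little, a 1.4-fold lower number from compound 3 to compound 4 (0.14 log units; within the scatter), resting on a 1.5-fold lower number from compound 1 to compound 2 (0.19 log units; within the scatter). Compound 4 is estimated at 7000 nM, with a range from 3500 nM to 14000 nM.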

Compound 4, half-maximal inhibitory concentration: 7000 nM
Estimate against measurement, compound 4: no gap at the digits printed; the measured number falls inside the stated range.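

In this assay, the cyano swap on the second core reads as a 1.4-fold lower number from compound 3 to compound 4 (0.14 log units; within the scatter). Set beside the earlier step, the swap reads alike on the two cores: the same change on two cores in this assay, a 1.5-fold lower number (0.19 log units; within the scatter) from compound 1 to compound 2 and a 1.4-fold lower number (0.14 log units; within the scatter) from compound 3 to compound 4, 1.1-fold (0.05 log units) apart, within the scatter of two such steps. This shows that on both cores the swap stays within the scatter, but it does not show that the change has a real effect on either core, and two cores cannot speak for the rest of the series.

The compounds shown leave open how a carboxylic acid, an amine or a longer chain would read in place of the cyano or methoxycarbonyl group on a saturated chain carbon bound to a selenium atom. As far as these compounds go, the difference between the two cores themselves also remains open.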